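A Chlorophenyl Swap Repeated on a Second Core

The source may report more compounds than this note shows. Statements on the series, on what has been measured and on what is new or still open speak of the compounds shown alone.

Three compounds have been measured in a functional assay on the whole organism (artery, strain albino) with Rattus norvegicus as the target, with a stated time of 60 min, at a dose of 10 mg/kg by the oral route; on this read-out higher numbers stand for more inhibition at the one dose given (going by the name of the read-out) and lower numbers for less inhibition:

Compound 1, `CC1=C(C(=O)Nc2ccc(F)cc2)C(c2ccc([N+](=O)[O-])cc2)N=C(SCc2cccc(Cl)c2)N1`, gives 7.2%.
Compound 2, `CC1=C(C(=O)Nc2ccc(F)cc2)C(c2ccc([N+](=O)[O-])cc2)N=C(SCc2ccc(Cl)cc2)N1`, gives 11.8%.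
Compound 3, `CC1=C(C(=O)Nc2ccc([N+](=O)[O-])cc2)C(c2ccc(Br)cc2)N=C(SCc2cccc(Cl)c2)N1`, gives 4.1%.

Compound 2 differs from compound 1 by 4-chlorophenyl in place of 3-chlorophenyl on a saturated chain carbon bound to a sulfur, and this change made a step of a number 4.6 percentage points higher from compound 1 to compound 2 (within the scatter). Compound 3 rests on a different core; how its core differs from that of compound 1 is not broken down here. Compound 4, `CC1=C(C(=O)Nc2ccc([N+](=O)[O-])cc2)C(c2ccc(Br)cc2)N=C(SCc2ccc(Cl)cc2)N1`, is not yet measured. It differs from compound 3 by 4-chlorophenyl in place of 3-chlorophenyl on a saturated chain carbon bound to a sulfur, the same change as between compound 1 and compound 2. Because the earlier step was a number 4.6 percentage points higher from compound 1 to compound 2 (within the scatter), a step of similar size, a number 4.4 percentage points higher from compound 3 to compound 4 (within the scatter), is expected from compound 3 to compound 4 in this assay. Compound 4 is therefore estimated at 8.5%, between 0% and 20%.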

Compound 4, a percentage reported as inhibition, in the whole organism at one dose (the size of the read-out at that dose, not a potency): 10.8%
For compound 4 the middle estimate is 2.3 percentage points below the measured one, within the range that was stated.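

In this assay the change from 3-chlorophenyl to 4-chlorophenyl on a saturated chain carbon bound to a sulfur gave a number 6.7 percentage points higher from compound 3 to compound 4 (within the scatter) on the second core. Set side by side, the steps on the two cores do not differ: the same change on two cores in this assay, a number 4.6 percentage points higher (within the scatter) from compound 1 to compound 2 and a number 6.7 percentage points higher (within the scatter) from compound 3 to compound 4, 2.1 percentage points apart, within the scatter of two such steps. This shows that the change reads alike on these two cores, but since each step lies within the scatter, it does not show that the change itself raises inhibition, nor that it would carry to any further core.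

The compounds shown leave open how an amine, a carboxylic acid or a longer chain in place of the chlorophenyl would read. From the compounds shown here alone, whether the two steps would still agree at another dose also remains open.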